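The compounds below may be only part of what the source reports. "The series", "measured", "known", "first", "only" and "open" are said of these compounds alone.

Working notes on the series. Three compounds share one core and differ only in the aryl group on the amide-type nitrogen. Compound 1 `COc1ccc(NC(=O)CN2CCN(c3nnc(Cc4ccccc4)c4ccccc34)CC2)cc1OC` gives 32200 nM in a functional assay on MDA-MB-231 cells (Homo sapiens) for cytotoxicity, read by MTT assay, with a stated time of 72 h; a lower number here means a stronger inhibitor, a higher number a weaker inhibitor. Compound 2 `O=C(CN1CCN(c2nnc(Cc3ccccc3)c3ccccc23)CC1)Nc1cccc(Br)c1` gives 3880 nM in this assay, and compound 3 `O=C(CN1CCN(c2nnc(Cc3ccccc3)c3ccccc23)CC1)Nc1cccc(F)c1` gives 3730 nM in this assay. The two single-site steps from compound 1 are alike in size: an 8.3-fold lower number from compound 1 to compound 2 (0.92 log units; beyond the scatter) and an 8.6-fold lower number from compound 1 to compound 3 (0.94 log units; beyond the scatter). Between the two halogenated analogues there is nothing to separate: a 1.0-fold lower number from compound 2 to compound 3 (0.02 log units; within the scatter). Compound 3 therefore shows the lowest number of the three, within the scatter of compound 2 and well apart from compound 1.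

Compound 4 `O=C(CN1CCN(c2nnc(Cc3ccccc3)c3ccccc23)CC1)Nc1cc(C(F)(F)F)ccc1Cl` is the next analogue. The change from compound 3 is 2-chloro-5-(trifluoromethyl)phenyl in place of 3-fluorophenyl on an amide-type nitrogen. Within the data shown here, the only step that touches a change on that ring while keeping a halogen, a 1.0-fold lower number from compound 2 to compound 3 (0.02 log units; within the scatter), lay within the scatter, whereas the steps that swapped the whole substitution pattern, an 8.3-fold lower number from compound 1 to compound 2 (0.92 log units; beyond the scatter) and an 8.6-fold lower number from compound 1 to compound 3 (0.94 log units; beyond the scatter), were modest but clear. Among the measured compounds shown here, no measured step covers a trifluoromethyl or a second substituent on the ring, so the direction is open; the expected step in this assay is a 1.1-fold higher number from compound 3 to compound 4 (0.03 log units; within the scatter). Compound 4 is thus estimated at 4000 nM, with a range of 1300 nM to 12000 nM.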

Compound 4, half-maximal inhibitory concentration: 19500 nM
For compound 4 the middle estimate is 4.9-fold (0.69 log units) below the measured one; measured number above the stated range.
By their numbers in this assay, from the lowest: compounds 3 and 2 (each within the scatter of the next); then compounds 4 and 1 (each within the scatter of the next).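

At the amide-type nitrogen, a halogen-bearing aryl group does not guarantee the lower numbers of compound 2 and compound 3 in this assay: the result gives a 5.2-fold higher number from compound 3 to compound 4 (0.72 log units; beyond the scatter) and a 5.0-fold higher number from compound 2 to compound 4 (0.70 log units; beyond the scatter), both beyond the scatter. The last comparison, a 1.7-fold lower number from compound 1 to compound 4 (0.22 log units; within the scatter), lies within the scatter, so 2-chloro-5-(trifluoromethyl)phenyl and 3,4-dimethoxyphenyl cannot be separated here, although the aryl groups of compound 1 and compound 4 share no substituent. Nothing available explains these steps.

The chloro and the trifluoromethyl enter together, so the compounds shown cannot assign the step to either one alone. From the compounds shown here alone, how this assay would read an aryl group carrying an amine or a carboxylic acid also stays open.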